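The source may hold more compounds than are shown below. What is called first, only, known or untested is meant among the compounds shown, and "the series" means these compounds.

The three measured compounds share one core. Compound 1 `CC(=O)c1cccc(Nc2ccnc(SCC(=O)c3ccc(-c4ccccc4)cc3)n2)c1` gives 49% in a functional assay on T47D cells (Homo sapiens) for inhibition, read by sulforhodamine B assay, with a stated time of 48 h, tested at 10 uM (a lower number here means less inhibition of growth, a higher number more inhibition of growth at the concentration tested), the second highest of the three numbers. Compound 3 `CCOC(=O)c1ccc(Nc2ccnc(SCC(=O)c3ccc([N+](=O)[O-])cc3)n2)cc1` gives 60%, higher beyond the scatter, and compound 2 `CC(=O)c1cccc(Nc2ccnc(SCC(=O)c3ccc(C(F)(F)F)cc3)n2)c1` gives 37%, lower beyond the scatter. Within the data shown here, the one measured step, a number 12 percentage points lower from compound 1 to compound 2 (beyond the scatter), sits at the other end of the molecule and does not bear on the change examined here. Compound 4 `CC(=O)c1ccc(Nc2ccnc(SCC(=O)c3ccc(-c4ccccc4)cc3)n2)cc1` differs from compound 1 by 4-acetylphenyl in place of 3-acetylphenyl on a nitrogen on an aromatic ring. Among the measured compounds shown here, no measured step touches that place, so nothing in the data points to a direction, and the expected step is none beyond the scatter. Compound 4 is therefore expected to give about 49% in this assay, within 35% to 63%. The estimated step is no change at the digits printed from compound 1 to compound 4 (within the scatter).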

Compound 4, percent growth inhibition at one concentration: 29%
Compound 4: the middle estimate sits 20 percentage points above what was measured, and the stated range ends above it.
By their numbers in this assay, from the lowest: compounds 4 and 2 (each within the scatter of the next); then compound 1; then compound 3.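

With the same atoms joined differently, 4-acetylphenyl in place of 3-acetylphenyl on the nitrogen gives a number 20 percentage points lower from compound 1 to compound 4 (beyond the scatter) in this assay. Among these compounds, this place on the shared core therefore responds to where the acetyl group stands, not only to which atoms are present, which no earlier step could show. Nothing measured here accounts for the step. Still open, from the compounds shown here alone, is how an amine or a carboxylic acid in place of the acetyl group would read in this assay, and whether the step holds with trifluoromethyl in place of the terminal phenyl.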